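A few compounds are considered here, and "the series" means these few. Any claim that something is new, unique, unknown or untested is made for them only; others in the source may bear on it.

Measured so far in a functional assay on the whole organism with Rattus norvegicus as the target; on this read-out higher numbers stand for an effect only at larger amounts of compound and lower numbers for an effect already at smaller amounts:
compound 1 `CC1CCC(/C=N/c2ccc(F)cc2)=C2NC=C(C(=O)O)C(=O)N21` gives 10.6 umol/kg;
compound 2 `CC1CCC(/C=N/c2ccccc2O)=C2NC=C(C(=O)O)C(=O)N21` gives 4.11 umol/kg;
compound 3 `Cc1cccc(/N=C/C2=C3NC=C(C(=O)O)C(=O)N3C(C)CC2)c1` gives 0.8 umol/kg.

Compound 1 stands at the highest number of the three, so it needs the largest dose. Both changes made to it at the ring on the double-bonded nitrogen lowered the number: a 2.6-fold lower number from compound 1 to compound 2 (0.41 log units; beyond the scatter) and a 13-fold lower number from compound 1 to compound 3 (1.12 log units; beyond the scatter). Compound 4 `CC(=O)c1ccc(/N=C/C2=C3NC=C(C(=O)O)C(=O)N3C(C)CC2)cc1` differs from compound 1 by acetyl in place of fluoro on an aromatic carbon. Neither measured step swaps a group at this same place for an acetyl, so they bear only loosely on it; they show that altering this ring has so far lowered the number by modest to large amounts. A modest lowering is therefore expected, a 1.8-fold lower number from compound 1 to compound 4 (0.25 log units; within the scatter), with wide uncertainty. Compound 4 is estimated at 6 umol/kg, between 2 umol/kg and 20 umol/kg.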

Compound 4, dose for 50% inhibition: 0.75 umol/kg
Compound 4: the middle estimate sits 8.0-fold (0.90 log units) above what was measured; the measured number lies below the stated range.
By their numbers in this assay, from the lowest: compounds 4 and 3 (each within the scatter of the next); then compound 2; then compound 1.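

In this assay, keeping the substituent on the same aromatic carbon, para to a large group, and changing only the group gives a 14-fold lower number from compound 1 to compound 4 (1.15 log units; beyond the scatter) here. Unlike compounds 2 and 3, which also place their group elsewhere on the ring, this shows that the group at this one place can by itself shift the dose needed by a large amount, and that the larger acetyl is accepted there. No measurement shown explains this shift.

Going by these compounds, whether the carbonyl of acetyl or simply its larger size matters remains open. An amine, a carboxylic acid or a longer chain at this carbon could help to separate the two.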